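The source may report more compounds than this note shows. Statements on the series, on what has been measured and on what is new or still open speak of the compounds shown alone.

Measured so far:
compound 1, `COc1ccc(-c2nn(-c3ccc(Cl)cc3)cc2C(CC(=O)c2ccc(Cl)cc2)C(=O)c2ccc(F)cc2)cc1`, 37.8%
compound 2, `COc1ccc(C(=O)C(CC(=O)c2ccc(Cl)cc2)c2cn(-c3ccc(Cl)cc3)nc2-c2ccc(OC)cc2)cc1`, 9.61%
compound 3, `Cc1ccc(-c2nn(-c3ccc(S(N)(=O)=O)cc3)cc2C(CC(=O)c2ccc(Cl)cc2)C(=O)c2ccc(F)cc2)cc1`, 56.2%

All three were tested in a functional assay on the whole organism (strain Wistar albino) for inhibition, with Rattus norvegicus as the target, read by paw edema, with stated times of 1 h and 3 h, at a dose of 0.32 mmol/kg by the intraperitoneal route; a higher number here means more inhibition at the dose given (going by the name of the read-out), a lower number less inhibition. Compound 3 gives the highest reading, 56.2%; compound 1 gives 37.8% and compound 2 gives 9.61%, each lower by more than the usual scatter.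

Compounds 1 and 2 differ in one place: methoxy in place of fluoro on an aromatic carbon. This change brings a number 28.2 percentage points lower from compound 1 to compound 2 (beyond the scatter).

Compound 4, `COc1ccc(C(=O)C(CC(=O)c2ccc(Cl)cc2)c2cn(-c3ccc(S(N)(=O)=O)cc3)nc2-c2ccc(C)cc2)cc1`, has not been measured yet. It stands to compound 3 as compound 2 stands to compound 1: methoxy in place of fluoro on an aromatic carbon. The change is the same, and the place where it sits is described in the same words. The difference between the core of compound 3 and the core of compound 1 is not broken down here.

Among the compounds with values here, because the one measured example of this change is a number 28.2 percentage points lower from compound 1 to compound 2 (beyond the scatter), a drop of about the same size is expected from compound 3 to compound 4, a number 26.2 percentage points lower from compound 3 to compound 4 (beyond the scatter). Since that rests on a single pair, the expected range is kept wide. Compound 4 is therefore estimated to give 30% in this assay, most likely between 12% and 48%.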

Compound 4, a percentage reported as inhibition, in the whole organism at one dose (the size of the read-out at that dose, not a potency): 61.1%
Compound 4: middle estimate off by 31.1 percentage points, on the low side; the whole stated range lies below it.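

Putting methoxy in place of fluoro in this assay gives a number 4.9 percentage points higher from compound 3 to compound 4 (within the scatter), so the change that lowered the reading on the core of compound 1 makes no clear difference on the core of compound 3. Within the data shown here, the effect of this change therefore does not carry over unchanged from one core to the other: the same change on two cores in this assay, a number 28.2 percentage points lower (beyond the scatter) from compound 1 to compound 2 and a number 4.9 percentage points higher (within the scatter) from compound 3 to compound 4, 33.1 percentage points apart, beyond the scatter of two such steps This shows that the outcome of the change depends on the core it sits on, but it rests on only two pairs and does not show which difference between the two cores is responsible, or how the change would read on a further core.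

The compounds shown carry only fluoro or methoxy on this aromatic carbon, so it stays open how a hydroxyl, a dimethylamino group or a carboxylic acid there would read on either core. Also open, on these data alone, is how the change would read on a core that differs from the core of compound 1 in one place only.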